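The compounds below may be only part of what the source reports. "The series", "measured", "known", "first", "only" and "open" are said of these compounds alone.

Of the compounds shown here, three have been measured in a functional assay on MCF7 cells (Homo sapiens) for inhibition, read by sulforhodamine B assay, with a stated time of 48 h; a lower number here means a stronger inhibitor of growth, a higher number a weaker inhibitor of growth. Compound 1 `Ic1ccc(NC2=NCCO2)cc1` gives 2900 nM in this assay. Compound 2 `Cc1ccc(NC2=NCCO2)cc1` gives 27000 nM in this assay. Compound 3 `O=C(CCl)NC(=O)Nc1ccc(I)cc1` gives 6800 nM in this assay. The step of a 9.3-fold higher number from compound 1 to compound 2 (0.97 log units; beyond the scatter) comes from one change, (methyl in place of iodo on an aromatic carbon), and it leaves compound 2 as the weakest of the three by a margin beyond the scatter. Compound 3 sits between the other two, and the difference between its core and the core of compound 1 is not broken down here.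

Compound 4 `Cc1ccc(NC(=O)NC(=O)CCl)cc1` has not yet been measured. It arises from compound 3 by methyl in place of iodo on an aromatic carbon. For the measured compounds named here, this is the same kind of change as the one from compound 1 to compound 2, though the surroundings differ: in compound 1 the change is para to a group of 6 heavy atoms, in compound 3 it is para to a group of 8 heavy atoms, and the cores themselves differ in a way not counted here.

Going by the values given here, with only one earlier example on a different core, the expectation rests on that single step. The step from compound 3 to compound 4 is expected to be a 5.9-fold higher number from compound 3 to compound 4 (0.77 log units; beyond the scatter), in the same direction as a 9.3-fold higher number from compound 1 to compound 2 (0.97 log units; beyond the scatter) but judged with caution. On that basis compound 4 is estimated to give about 40000 nM, with a plausible range from 15000 nM to 120000 nM.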

Compound 4, concentration for 50% growth inhibition: 7500 nM
Compound 4: middle estimate off by 5.3-fold (0.73 log units), on the high side, and the stated range ends above it.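

In this assay, placing methyl instead of iodo on the aromatic carbon gives a 1.1-fold higher number from compound 3 to compound 4 (0.04 log units; within the scatter) and so compound 3 and compound 4 cannot be told apart in this test. The large step seen on the core of compound 1 therefore does not carry over in size to the core of compound 3, which is a warning against moving a result from one core to another in this series: the same change on two cores in this assay, a 9.3-fold higher number (0.97 log units; beyond the scatter) from compound 1 to compound 2 and a 1.1-fold higher number (0.04 log units; within the scatter) from compound 3 to compound 4, 8.4-fold (0.93 log units) apart, beyond the scatter of two such steps. These two pairs show that the outcome of this swap differs between the two cores, but they do not show which part of the cores accounts for the difference, and two steps are too few to say which result is more typical of the series.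

The compounds shown leave open how other groups at the same place, such as chloro, methoxy, an amine or a carboxylic acid, would compare on the two cores. They also leave open how much the chlorine-bearing end of compound 3 and compound 4 contributes to their growth inhibition, which could be probed by a longer chain at that end or by hydrogen in place of the chlorine.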